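The source may hold more compounds than are shown below. What is called first, only, known or untested is meant among the compounds shown, and "the series" means these compounds.

Measured compounds: compound 1 `Cc1cc(=O)oc2cc(OC3CCCCC3=O)ccc12` with 43000 nM; compound 2 `COc1cc(OC2CCCCC2=O)cc2oc(=O)cc(C)c12` with 21400 nM; compound 3 `COc1cc(OC2CCCCC2=O)c2c(C)cc(=O)oc2c1`, whose value is a limit of the assay, > 200000 nM.

In an assay on isolated protein for inhibition of Amine oxidase [flavin-containing] A (Homo sapiens) (on this read-out lower numbers stand for stronger inhibition and higher numbers for weaker inhibition), compound 1 stands highest of the two numbers given. Among the measured compounds shown here, the step of a 2.0-fold lower number from compound 1 to compound 2 (0.30 log units; within the scatter) is the only measured change with one difference. Compound 4 `COc1c(OC2CCCCC2=O)ccc2c(C)cc(=O)oc12` differs from compound 1 by methoxy in place of hydrogen on an aromatic carbon. The methoxy of compound 4 sits at a different place from that of compound 2, so the measured step guides only loosely; it suggests that a methoxy on the shared core changes little. Compound 4 is therefore expected to lie close to compound 1, with a 1.1-fold lower number from compound 1 to compound 4 (0.03 log units; within the scatter) expected to stay within the scatter. The estimate for compound 4 is 40000 nM, expected between 13000 nM and 130000 nM.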

Compound 4, half-maximal inhibitory concentration: 11100 nM
For compound 4 the middle estimate is 3.6-fold (0.56 log units) above the measured one; the measured number lies below the stated range.
By their numbers in this assay, from the lowest: compounds 4, 2 and 1 (each within the scatter of the next, the first and the last beyond it). At a limit, above all of these: compound 3.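

Methoxy in place of hydrogen on the aromatic carbon ortho to a fused ring and ortho to the group of 8 heavy atoms gives a 3.9-fold lower number from compound 1 to compound 4 (0.59 log units; beyond the scatter) in this assay, whereas the other single methoxy step gives a 2.0-fold lower number from compound 1 to compound 2 (0.30 log units; within the scatter). At this position, then, the change has a modest effect that lies beyond the scatter. No measured property shown here bears on this step.

The compounds shown leave open whether an ethoxy group or an amine in place of the methoxy of compound 4 would preserve this step.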